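The compounds below may be only part of what the source reports. "The series", "measured", "known", "first", "only" and "open" are said of these compounds alone.

Measured compounds in a functional assay on CWR22R cells (Homo sapiens) for antiproliferative activity; on this read-out higher numbers stand for weaker inhibition and lower numbers for stronger inhibition:
- compound 2, `CC(O)(C[S+]([O-])c1ccc(F)cc1F)C(=O)Nc1ccc([N+](=O)[O-])cc1C(F)(F)F`, gives 51100 nM
- compound 1, `CC(O)(C[S+]([O-])c1ccc(C(F)(F)F)cn1)C(=O)Nc1ccc([N+](=O)[O-])cc1C(F)(F)F`, gives > 100000 nM; > 100000 nM (2 entries)
- compound 3, `CC(O)(C[S+]([O-])c1ccccn1)C(=O)Nc1ccc(C#N)c(C(F)(F)F)c1`, gives only a limit, > 100000 nM

Compound 2 holds the only number shown; the other two entries are limits rather than numbers. Compound 4, `CC(O)(C[S+]([O-])c1ccccn1)C(=O)Nc1ccc([N+](=O)[O-])cc1C(F)(F)F`, differs from compound 2 by pyridin-2-yl in place of 2,4-difluorophenyl on a sulfur. For the measured compounds named here, no step between measured compounds is available. Compound 1 shares the core of compound 2 with a different group on the sulfur and sits at the limit of > 100000 nM in this assay, at which 1 of the 3 values shown sits. Compound 3 carries pyridin-2-yl on the sulfur and likewise gives only a limit. Compound 4 is therefore expected to be weaker, with an expected step of a 2.0-fold higher number from compound 2 to compound 4 (0.29 log units; within the scatter) in this assay. Compound 4 is estimated at 100000 nM, within 40000 nM to 300000 nM, with a fair chance of only a limit being reported.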

Compound 4, half-maximal inhibitory concentration: > 100000 nM
Compound 4: only a limit was reported (the forecaster's own chance of this, stated with the estimate: 60%); the middle value lies on the limit itself.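

In this assay, for the compounds shown here, pyridin-2-yl in place of 2,4-difluorophenyl on a sulfur gives the first direct comparison at this position: an at least 1.9-fold higher number from compound 2 to compound 4 (0.29 log units; that floor lies within the scatter). Only this floor can be read, so the change is not shown to weaken activity, and the true size of the step remains unknown. Compound 4 adds to the entries that are limits: the limit of > 100000 nM in this assay, at which 2 of the 4 values shown sit.

The compounds shown leave open whether the ring nitrogen or the two fluorines matter more, as the change alters both at once. A plain phenyl on the sulfur would separate the two.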